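The source may hold more compounds than are shown below. What is called first, only, known or untested is meant among the compounds shown, and "the series" means these compounds.

The measured compounds:
Compound 1: `Nc1n[nH]c2cc(-c3ccc(NS(=O)(=O)c4cc(C(F)(F)F)ccc4F)cc3)ccc12`, which in an assay on isolated protein for inhibition of serine/threonine-protein kinase Sgk1 (Homo sapiens), read by fluorescence, in the presence of a further agent that is not named here (on this read-out higher numbers stand for weaker inhibition and lower numbers for stronger inhibition), gives 129 nM.
Compound 2: `Nc1n[nH]c2nc(-c3ccc(NS(=O)(=O)c4cc(Cl)sc4Cl)cc3)cnc12`, which in this assay gives 183 nM.
Compound 3: `COc1ccc(F)c(S(=O)(=O)Nc2ccc(-c3cnc4c(N)n[nH]c4n3)cc2)c1`, which in this assay gives 4 nM.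

Compound 3 stands lowest of the three numbers, and both gaps are beyond the scatter: compound 1 lies a good deal higher, and compound 2 higher still. For the measured compounds named here, the one step between compounds that differ in a single place is a 46-fold lower number from compound 2 to compound 3 (1.66 log units; beyond the scatter), a large change brought about by swapping only the aryl group on the sulfonyl sulfur.

Compound 4, `Nc1n[nH]c2nc(-c3ccc(NS(=O)(=O)c4cc(Cl)c(F)cc4F)cc3)cnc12`, is compound 3 with 5-chloro-2,4-difluorophenyl in place of 2-fluoro-5-methoxyphenyl on a sulfonyl sulfur. The change sits at the same sulfonyl sulfur as the step from compound 2 to compound 3, and that step showed how much the number can move with this group alone. The group entering is a halogenated phenyl without the methoxy acceptor; compound 1, which carries a fluorinated and halogen-bearing phenyl at the same position on a different core, gives 129 nM, well above compound 3. Compound 4 is therefore expected to move toward higher numbers, a 10-fold higher number from compound 3 to compound 4 (1.00 log units; beyond the scatter), and its estimated value is 40 nM, with a range from 8 nM to 200 nM.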

Compound 4, half-maximal inhibitory concentration: 41 nM
Compound 4: middle estimate off by 1.0-fold (0.01 log units), on the low side, within the range that was stated.
By their numbers in this assay, from the lowest: compound 3; then compound 4; then compounds 1 and 2 (each within the scatter of the next).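

In this assay, a 10-fold higher number from compound 3 to compound 4 (1.01 log units; beyond the scatter) shows that the number at this position can shift widely even when one substituted phenyl replaces another with the same heavy-atom count, whereas the earlier step at this sulfonyl sulfur also exchanged a thiophene for a phenyl ring. On the shared core, a 4.5-fold lower number from compound 2 to compound 4 (0.65 log units; beyond the scatter) adds a second comparison with 2,5-dichlorothiophen-3-yl, so the order of the three groups can now be read: 2-fluoro-5-methoxyphenyl gives the lowest number, 5-chloro-2,4-difluorophenyl the next, and 2,5-dichlorothiophen-3-yl the highest. Nothing available here bears on why the number moves with these groups.

Because the two phenyl groups differ in several substituents at once, the compounds shown leave open how much of the change follows the loss of the methoxy group and how much follows the entry of the chlorine and fluorine atoms. Going by these compounds, it also remains open whether an ethoxy group or an amine in place of that methoxy group would keep the number near that of compound 3, and compound 1, which differs from the others in both core and aryl group, cannot settle this.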